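From 4-fluorophenyl to 3-chloro-4-fluorophenyl: working notes

The source may hold more compounds than are shown below. What is called first, only, known or untested is meant among the compounds shown, and "the series" means these compounds.

Among the measured compounds shown here, the series so far holds compound 1 `O=C(/C=C/c1cccnc1)NCCCCCCc1cccc(S(=O)(=O)Nc2ccccc2)c1` and compound 2 `O=C(/C=C/c1cccnc1)NCCCCCCc1cccc(S(=O)(=O)Nc2ccc(F)cc2)c1` as measured members, while compound 3 `O=C(/C=C/c1cccnc1)NCCCCCCc1cccc(S(=O)(=O)Nc2ccc(F)c(Cl)c2)c1` is still unmeasured. In a functional assay on K562 cells (Homo sapiens) for inhibition, read by CCK-8 assay, with a stated time of 72 h (on this read-out higher numbers stand for weaker inhibition and lower numbers for stronger inhibition), compound 1 gives 0.88 nM and compound 2 gives 0.93 nM so that compound 2 stands level with compound 1, the two lying within the scatter of each other.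

The change at hand, 4-fluorophenyl to 3-chloro-4-fluorophenyl, is chloro in place of hydrogen on an aromatic carbon and it puts the chloro ortho to a fluoro group and meta to a large group. For the measured compounds named here, only one measured step bears on it, fluoro in place of hydrogen on an aromatic carbon, namely a 1.1-fold higher number from compound 1 to compound 2 (0.02 log units; within the scatter) and that step stays within the scatter. Going by the values given here, no chloro compound has been measured yet, so the evidence is thin. No step beyond the scatter is therefore expected in this assay and no direction is favoured. The expected step is a 1.1-fold higher number from compound 2 to compound 3 (0.03 log units; within the scatter) and it is an estimate only. Compound 3 is estimated at 1 nM with 0.4 nM to 2.5 nM as the expected range.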

Compound 3, half-maximal inhibitory concentration: 5.31 nM
Estimate against measurement, compound 3: 5.3-fold (0.73 log units) below; measured number outside the range, above it.
By their numbers in this assay, from the lowest: compounds 1 and 2 (each within the scatter of the next); then compound 3.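

Working notes after compound 3: in this assay, chloro in place of hydrogen on an aromatic carbon, ortho to a fluoro group and meta to a large group, gives a 5.7-fold higher number from compound 2 to compound 3 (0.76 log units; beyond the scatter) and is the first change in the series to move the number beyond the scatter. Fluoro in place of hydrogen gave only a 1.1-fold higher number from compound 1 to compound 2 (0.02 log units; within the scatter) and stayed within the scatter, whereas the 3-chloro-4-fluorophenyl group in place of phenyl gives a 6.0-fold higher number from compound 1 to compound 3 (0.78 log units; beyond the scatter) and so the higher number appears in these compounds only once the chloro is present. This position on the sulfonamide nitrogen's substituent therefore responds to the change, and nothing on hand accounts for the step.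

On these data alone, whether the step belongs to the chloro alone or to the chloro together with the fluoro group stays open, and a 3-chlorophenyl group would separate the two. Also open, as far as these compounds go, is how a methyl, a methoxy or an amine at the same place would read in this assay and whether a larger halogen such as bromo would give a step of the same direction.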